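The source may report more compounds than this note shows. Statements on the series, on what has been measured and on what is new or still open speak of the compounds shown alone.

Among the compounds with values here, in a functional assay on Raji cells (Homo sapiens) for cytotoxicity, with a stated time of 72 h (on this read-out higher numbers stand for an effect only at larger amounts of compound and lower numbers for an effect already at smaller amounts), none of the three compounds tested so far gives a number. Compound 1 (`C=C[C@@](C)(/C=C/c1ccc(O)c(/C=C/C(=O)OCC)c1)CCC=C(C)C`) sits at a limit of the assay (> 26000 nM). Compound 2 (`C=C[C@@](C)(/C=C/c1ccc(O)c(/C=C/c2ccc(Cl)cc2)c1)CCC=C(C)C`) also sits at a limit (> 26000 nM). Compound 3 (`CCOC(=O)/C=C/c1cc(/C=C/[C@](C)(/C=C/c2ccc(OC)cc2)CCC=C(C)C)ccc1O`) likewise sits at a limit (> 26000 nM), so its position is known only as a limit, and the other two share that position (the limit of > 26000 nM in this assay, at which 3 of the 3 values shown sit).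

Compound 4 (`COc1ccc(/C=C/[C@@](C)(/C=C/c2ccc(O)c(/C=C/C(C)=O)c2)CCC=C(C)C)cc1`) differs from compound 3 by methyl in place of ethoxy on a carbonyl carbon, which turns ethoxycarbonyl into acetyl (methyl in place of ethoxy on a carbonyl carbon). The closest measured change also alters the ethoxycarbonyl group, replacing it outright (a step that the two limits leave unreadable from compound 1 to compound 2). The other measured change lies elsewhere in the structure (a step that the two limits leave unreadable from compound 1 to compound 3). Neither has a readable size, so neither gives a measured direction or magnitude for the new change. No step beyond the scatter can be argued from them, and the most likely outcome is another limit. The expected size is a number no higher from compound 3 to compound 4 (the limit leaves the size open) on this reasoning, with no direction favoured. Compound 4 is estimated at 26000 nM in this assay, with an expected range from 10000 nM to 60000 nM around that estimate.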

Compound 4, half-maximal effective concentration: > 26000 nM
Compound 4 gave a limit, no number; the forecaster's own chance of this, stated with the estimate: 75%; the middle value sits exactly at the limit.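

Compound 3 and compound 4 each give only a limit in this assay, so the change from ethoxycarbonyl to acetyl has no readable size. The same holds across the series: the limit of > 26000 nM in this assay, at which 4 of the 4 values shown sit.

The compounds shown leave open how these four rank against one another and whether any change to the shared core would give a number on this read-out.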